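The source may hold more compounds than are shown below. What is called first, only, known or untested is meant among the compounds shown, and "the series" means these compounds.

Measured compounds:

Compound 1, `CN(c1ccc(Oc2ncnc3ccsc23)cc1)c1nccc(N2CCCC2)n1`: in a functional assay on A549 cells (Homo sapiens) for inhibition, read by MTT assay, with a stated time of 72 h (on this read-out higher numbers stand for weaker inhibition and lower numbers for stronger inhibition), compound 1 gives 6510 nM.
Compound 2, `CN(c1ccc(Oc2ncnc3ccsc23)cc1)c1nccc(N2CCCCC2)n1`: in this assay compound 2 gives 8240 nM.
Compound 3, `c1cc(N2CCCCC2)nc(Nc2ccc(Oc3ncnc4ccsc34)cc2)n1`: in this assay compound 3 gives 7800 nM.

The three measured compounds share a core and lie close together in this assay. Compound 3 differs from compound 2 by hydrogen in place of methyl on a nitrogen on an aromatic ring, and this gave a 1.1-fold lower number from compound 2 to compound 3 (0.02 log units; within the scatter). Compound 1 differs from compound 2 by pyrrolidin-1-yl in place of piperidin-1-yl on an aromatic carbon, and this gave a 1.3-fold lower number from compound 2 to compound 1 (0.10 log units; within the scatter).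

Compound 4, `c1cc(N2CCCC2)nc(Nc2ccc(Oc3ncnc4ccsc34)cc2)n1`, has not been measured. It differs from compound 3 by pyrrolidin-1-yl in place of piperidin-1-yl on an aromatic carbon. This is the same change that separates compound 2 from compound 1, and the place line is identical word for word in both pairs. That earlier change gave a 1.3-fold lower number from compound 2 to compound 1 (0.10 log units; within the scatter), so the expected step from compound 3 to compound 4 in this assay is a 1.3-fold lower number from compound 3 to compound 4 (0.10 log units; within the scatter), resting on that single earlier step and on the value of compound 3, 7800 nM. The estimate for compound 4 in this assay is 6200 nM, expected to lie between 3000 nM and 12500 nM.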

Compound 4, half-maximal inhibitory concentration: "not active" (no number reported)
Compound 4: no number reported, so the estimate cannot be set against anything.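

In this assay, among these compounds, compound 4 is reported as "not active" with no number, so no step from compound 3 to compound 4 can be read. The compounds shown leave open whether replacing piperidin-1-yl with pyrrolidin-1-yl has the same size of effect in compound 4 as between compound 2 and compound 1. No evidence available here bears on this result.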